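The compounds below may be only part of what the source reports. "The series", "measured", "known", "first", "only" and "open" are said of these compounds alone.

Measured so far:
compound 1 `CCc1nn(C)c(CO/N=C/c2c(C)nn(C)c2Oc2ccc(I)cc2)c1Cl`: < 80%
compound 2 `CCc1nn(C)c(CO/N=C/c2c(C)nn(C)c2Oc2ccc(C)cc2)c1Cl`: < 80%

In a functional assay on SMMC-7721 cells (Homo sapiens) for inhibition, read by MTT assay, with a stated time of 72 h, tested at 25 uM (on this read-out higher numbers stand for more inhibition at the one concentration tested (going by the name of the read-out) and lower numbers for less inhibition), compound 1 gives < 80%, which is a limit of the assay. In this assay compound 2 gives < 80%, likewise a limit. The step that the two limits leave unreadable from compound 1 to compound 2 is therefore unreadable, both values sitting at the limit of < 80% in this assay, at which 2 of the 2 values shown sit. Compound 3 `CCc1nn(C)c(CO/N=C/c2c(C)nn(C)c2Oc2cccc(C)c2)c1Cl` differs from compound 2 by 3-methylphenyl in place of 4-methylphenyl on an oxygen on an aromatic ring. Going by the values given here, no measured step bears on this change, and the only recorded step gives no size. The step that the limit leaves unreadable from compound 2 to compound 3 is expected to stay within the scatter. Compound 3 is therefore expected at 40%, in the range 10% to 75%.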

Compound 3, a percentage reported as inhibition, at one concentration (the size of the read-out at that concentration, not a potency): < 80%
Compound 3 ended at the assay's limit; the forecaster's own chance of this, stated with the estimate: 85%; the middle value lies beyond the limit too.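

No new step can be read between compound 3 and compound 2 or compound 1, since each value is a limit of the assay in this assay: the limit of < 80% in this assay, at which 3 of the 3 values shown sit.

As far as these compounds go, how far inhibition shifts from 4-methylphenyl to 3-methylphenyl, and whether these three compounds differ at all, stays open.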